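Fluorine Position and Cytotoxicity in Three Close Analogues

This account rests on a few compounds, and the source may have more. Where it says the series, first, only, none or still open, it means among the compounds named here.

Compound 1 `COc1ccc(Nc2nnnn2-c2ccccc2F)cc1`: 122000 nM
Compound 2 `COc1ccc(Nc2nnnn2-c2cccc(Cl)c2)cc1`: 103000 nM
Compound 3 `COc1ccc(Nc2nnnn2-c2cccc(F)c2)cc1`: 101000 nM

In an ADME assay on HaCaT cells (Homo sapiens) for cytotoxicity, read by MTT assay, with a stated time of 72 h (on this read-out lower numbers stand for stronger inhibition and higher numbers for weaker inhibition), compound 3 gives 101000 nM, which cannot be told apart from the other two values. Those gaps are a 1.0-fold lower number from compound 2 to compound 3 (0.01 log units; within the scatter) and a 1.2-fold lower number from compound 1 to compound 3 (0.08 log units; within the scatter).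

Compound 4 `COc1ccc(Nc2nnnn2-c2ccc(F)cc2)cc1` keeps the shared core and changes one thing: 4-fluorophenyl in place of 3-fluorophenyl on an aromatic nitrogen. The closest measured change of the same kind is a 1.2-fold lower number from compound 1 to compound 3 (0.08 log units; within the scatter), where 3-fluorophenyl replaced 2-fluorophenyl. The other two steps, a 1.2-fold lower number from compound 1 to compound 2 (0.07 log units; within the scatter) and a 1.0-fold lower number from compound 2 to compound 3 (0.01 log units; within the scatter), also stay small. Within the data shown here, no compound with a 4-fluorophenyl group has been measured yet, so this remains an expectation, with no step beyond the scatter anticipated in this assay. The estimated step is a 1.0-fold higher number from compound 3 to compound 4 (0.02 log units; within the scatter). Compound 4 is expected at 105000 nM, with an estimated range of 60000 nM to 180000 nM.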

Compound 4, half-maximal inhibitory concentration: 101000 nM
Estimate against measurement, compound 4: 1.0-fold (0.02 log units) above; measured number inside the range.
By their numbers in this assay, from the lowest: compounds 3, 4, 2 and 1 (each within the scatter of the next).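

With the 4-fluorophenyl group in place of 3-fluorophenyl, this assay shows no change at the digits printed from compound 3 to compound 4 (within the scatter) on moving the fluoro group. The other new comparisons agree, with a 1.0-fold lower number from compound 2 to compound 4 (0.01 log units; within the scatter) and a 1.2-fold lower number from compound 1 to compound 4 (0.08 log units; within the scatter) both showing that compound 4 joins the others, with no step among these four compounds leaving the scatter. Nothing available explains this flat picture. Still open, from the compounds shown here alone, is whether a different kind of group on this phenyl ring, such as an amine or a carboxylic acid, would produce a step beyond the scatter.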